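Fluoro on the Anilide Ring and a Drawn Configuration

This account rests on a few compounds, and the source may have more. Where it says the series, first, only, none or still open, it means among the compounds named here.

Compound 1 `C/C(=N/NC(=S)Nc1ccccc1F)c1ccccn1` gives 0.39 nM in a functional assay on MCF7 cells (Homo sapiens) for cytotoxicity, read by MTT assay, with a stated time of 48 h; a lower number here means a stronger inhibitor, a higher number a weaker inhibitor.
Compound 2 `C/C(=N/NC(=S)Nc1ccccc1)c1ccccn1` gives 0.18 nM in this assay.
Compound 3 `C/C(=N\NC(=S)Nc1ccccc1)c1ccccn1` gives 0.18 nM in this assay.

Compound 3 and compound 2 differ only in this way: the two compounds have the same atoms and bonds and differ only in configuration as drawn: 1 of 1 stereo elements differ; a double bond is drawn Z in compound 2 and E in compound 3. In this assay the step is no change at the digits printed from compound 2 to compound 3 (within the scatter), in keeping with the fact that compounds 2 and 3 differ only in the configuration as drawn. From compound 2 to compound 1 the change is fluoro in place of hydrogen on an aromatic carbon, and the step is a 2.2-fold higher number from compound 2 to compound 1 (0.34 log units; beyond the scatter).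

Compound 4 `C/C(=N\NC(=S)Nc1ccc(F)cc1)c1ccccn1` has not yet been measured. From compound 3 it differs thus: fluoro in place of hydrogen on an aromatic carbon. The place is not the same word for word: ortho to a large group in compound 1, para to a large group in compound 4, so this is the same kind of change, not the same change. The expected step is a 1.9-fold higher number from compound 3 to compound 4 (0.29 log units; within the scatter), resting on a 2.2-fold higher number from compound 2 to compound 1 (0.34 log units; beyond the scatter) for the same kind of change. Compound 4 is expected at 0.35 nM, with a range from 0.15 nM to 0.8 nM.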

Compound 4, half-maximal inhibitory concentration: 1.2 nM
Compound 4: the middle estimate sits 3.4-fold (0.54 log units) below what was measured; measured number above the stated range.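

In this assay, fluoro in place of hydrogen on the aromatic carbon gives a 6.7-fold higher number from compound 3 to compound 4 (0.82 log units; beyond the scatter), so in these two cases the change moves the number in the same direction, but its size does not carry over from one core to the other: the same change on two cores in this assay, a 2.2-fold higher number (0.34 log units; beyond the scatter) from compound 2 to compound 1 and a 6.7-fold higher number (0.82 log units; beyond the scatter) from compound 3 to compound 4, 3.1-fold (0.49 log units) apart, beyond the scatter of two such steps. Two steps are too few to make a rule for the series. They also do not show whether the gap goes with the place of the fluoro, para to a large group in compound 4 but not in compound 1, or with the configuration as drawn, since the two steps differ in both.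

Still open, from the compounds shown here alone, is how the fluoro of compound 1 would read on the configuration drawn in compound 3. Also open, going by these compounds, is how chloro, methoxy or a carboxylic acid on the same ring would compare.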